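Sulfamate series: amine replacement on the aromatic ring

A few compounds are considered here, and "the series" means these few. Any claim that something is new, unique, unknown or untested is made for them only; others in the source may bear on it.

Measured compounds:
compound 1 `CN(C)CCN(CCN(C)C)c1ccc(C(=O)N2CCc3ccc(OS(N)(=O)=O)cc3C2)cc1`: 15.9%
compound 2 `NS(=O)(=O)Oc1ccc2c(c1)CN(C(=O)c1ccc(N3CCC(N4CCCCC4)CC3)cc1)CC2`: 53.7%

In an assay on HEK293 cells for inhibition of Steryl-sulfatase (Homo sapiens), tested at 1 uM (on this read-out higher numbers stand for a stronger effect at the one concentration tested and lower numbers for a weaker effect), compound 1 gives 15.9%, the lower of the two numbers in hand. Compound 2, carrying a different amine substituent, gives 53.7%, higher by an amount beyond the usual scatter. Going by the values given here, no step between these two measured compounds has been worked out, so the pair shows only that another amine can reach clearly higher inhibition in the same read-out.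

Compound 3 `CCCN(CCC)c1ccc(C(=O)N2CCc3ccc(OS(N)(=O)=O)cc3C2)cc1` is not yet measured. Relative to compound 1 it carries dipropylamino in place of bis(2-(dimethylamino)ethyl)amino on an aromatic carbon. The two values in hand give no direct guidance on this change. The step of a number 9.1 percentage points higher from compound 1 to compound 3 (within the scatter) is expected to be small, if anything upward, and may well remain within the scatter. Compound 3 is therefore estimated at 25%, with a range from 5% to 55%.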

Compound 3, a percentage reported as inhibition, at one concentration (the size of the read-out at that concentration, not a potency): 84.7%
For compound 3 the middle estimate is 59.7 percentage points below the measured one; the whole stated range lies below it.
By their numbers in this assay, from the lowest: compound 1; then compound 2; then compound 3.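

In this assay, dipropylamino in place of bis(2-(dimethylamino)ethyl)amino on an aromatic carbon, para to a large group, gives a number 68.8 percentage points higher from compound 1 to compound 3 (beyond the scatter), so the read-out at this position depends strongly on the amine substituent even with the core held constant. The change removes 11 heavy atoms, including 3 nitrogen atoms, and introduces 7 heavy atoms, including 1 nitrogen atom, and this single step cannot show which of these differences matters. No supporting data on the origin of the step are available.

Still open, from the compounds shown here alone, is whether the result depends on the propyl chains themselves or on the absence of the dimethylamino arms. Diethylamino, dibutylamino, or an amine carrying one propyl chain and one 2-(dimethylamino)ethyl chain would help separate these possibilities.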